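Hydroxy acyl series: neopentyl to tert-butyl at the carbinol

The compounds below may be only part of what the source reports. "The series", "measured", "known", "first", "only" and "open" are said of these compounds alone.

Measured compounds:
compound 1 `CC(C)(C)C[C@@H](O)C(=O)N1NCC[C@H]1C(=O)NCc1cc(Cl)ccc1-n1cnnn1`: 1300 nM
compound 2 `O=C(NCc1cc(Cl)ccc1-n1cnnn1)[C@@H]1C[C@@H]2C[C@@H]2N1C(=O)[C@H](O)CC1CC1`: 1700 nM

Of the compounds shown here, two have been measured in a functional assay on a cell-free system (plasma, Homo sapiens), with a stated time of 3 min; a lower number here means a stronger inhibitor, a higher number a weaker inhibitor. Compound 1 gives 1300 nM and compound 2 gives 1700 nM; compound 1 has the lowest of the two numbers, but the gap to compound 2 lies within the scatter of this assay, so the two cannot be ordered. Compound 1 and compound 2 differ in several places at once, and nothing is known about the contribution of any single one of them.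

The next compound, compound 3 `CC(C)(C)[C@@H](O)C(=O)N1NCC[C@H]1C(=O)NCc1cc(Cl)ccc1-n1cnnn1`, is derived from compound 1 by a single change: tert-butyl in place of neopentyl on a saturated chain carbon bound to a carbonyl carbon and an oxygen on a saturated carbon. The rest of the molecule, including the shared core and the chlorinated benzylamide bearing the tetrazole, is kept.

Within the data shown here, no measured pair in the set isolates this kind of change, so there is nothing to anchor the size of the step. The change is small and keeps the hydroxyl and the branching at the same carbon. The step from compound 1 to compound 3 in this assay is expected to be a 1.5-fold higher number from compound 1 to compound 3 (0.19 log units; within the scatter), a small shift towards a weaker inhibitor that may well stay within the scatter. Compound 3 is accordingly estimated at 2000 nM, with a range from 700 nM to 6000 nM.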

Compound 3, half-maximal inhibitory concentration: 1700 nM
Beside the measured number, compound 3's estimate is 1.2-fold (0.07 log units) above it; the range from low to high includes it.
By their numbers in this assay, from the lowest: compounds 1, 2 and 3 (each within the scatter of the next).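

In this assay, among these compounds, the step of a 1.3-fold higher number from compound 1 to compound 3 (0.12 log units; within the scatter) is the first reading that isolates one place, since compound 1 and compound 2 differ in several places at once. On a saturated chain carbon bound to a carbonyl carbon and an oxygen on a saturated carbon, neopentyl with 5 heavy atoms and tert-butyl with 4 heavy atoms cannot be told apart in this read-out, so no preference between the two groups can be stated, and the hydroxyl-bearing side chain accepts either of them on the shared core. No available evidence bears on why these two groups read alike.

These two groups are both saturated, all-carbon and close in size, so the comparison says little about how far this position responds to larger changes, and a longer chain, a phenyl ring, an amine or a carboxylic acid in the same place remains an open question. Also open, from the compounds shown here alone, is whether tert-butyl and neopentyl would read alike on the core of compound 2, and what the core itself contributes.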